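Methoxy to fluoro on the pendant phenyl: stability notes

A few compounds are considered here, and "the series" means these few. Any claim that something is new, unique, unknown or untested is made for them only; others in the source may bear on it.

Two cores carry the same pendant aryl group and the same four-carbon chain to phenyl. Compound 1 `O=C(NCCCCc1ccccc1)n1c(=O)oc2cc(-c3ccc(F)cc3)ccc21` and compound 2 `COc1ccc(-c2ccc3c(c2)oc(=O)n3C(=O)NCCCCc2ccccc2)cc1` share one core; compound 3 `COc1ccc(-c2ccc3oc(=O)n(C(=O)NCCCCc4ccccc4)c3c2)cc1` and compound 4 `O=C(NCCCCc1ccccc1)n1c(=O)oc2ccc(-c3ccc(F)cc3)cc21` share the other. How the two cores differ is not broken down here.

In a physicochemical assay for metabolic stability, read by HPLC, in phosphate buffer, at pH 7.4, tested at 10 uM (a lower number here means that the compound disappears faster, a higher number that the compound lasts longer), compound 1 reaches only a limit, > 5 h (the limit of > 5 h in this assay, at which 1 of the 3 values shown sits). In this assay compound 2 gives 2.2 h, and compound 3 gives 2.93 h. The values of compound 2 and compound 3 lie within the scatter of one another. The change fluoro in place of methoxy on an aromatic carbon gave an at least 2.2-fold higher number from compound 2 to compound 1 (0.35 log units; beyond the scatter).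

The change fluoro in place of methoxy on an aromatic carbon is the same change, at the same place on the other core. The expected step is a 2.2-fold higher number from compound 3 to compound 4 (0.35 log units; beyond the scatter), resting on an at least 2.2-fold higher number from compound 2 to compound 1 (0.35 log units; beyond the scatter), which is itself only a lower bound on account of the limit for compound 1. Compound 4 is expected to give 6.5 h in this assay, between 3.5 h and 12 h, with a fair chance that only a limit is reported.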

Compound 4, half-life: > 5 h
Compound 4: a limit, no number; the forecaster's own chance of this, stated with the estimate: 60%; the middle value is on the limit's open side.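

In this assay compound 4 gives > 5 h, which is a limit and not a number. Fluoro in place of methoxy gives an at least 1.7-fold higher number from compound 3 to compound 4 (0.23 log units; that floor lies within the scatter), which is compatible with an at least 2.2-fold higher number from compound 2 to compound 1 (0.35 log units; beyond the scatter) and suggests that the change carries over from one core to the other, but the floor of the new step does not on its own establish a real gain on this core. The sizes of the two steps cannot be compared, since neither has an upper end: the limit of > 5 h in this assay, at which 2 of the 4 values shown sit.

The compounds shown cover only two groups on the pendant phenyl, across two cores, so they leave open how far compound 1 and compound 4 really lie from one another and whether the pair behaves alike once both can be read as numbers. Also open, as far as these compounds go, is whether a chloro, a nitrile or an amine at the same place, or a longer chain to the terminal phenyl, would follow the same course in this assay.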